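This account rests on a few compounds, and the source may have more. Where it says the series, first, only, none or still open, it means among the compounds named here.

Measured compounds in the series:

Compound 1, `O=c1ccn(Cc2ncnc3c2ncn3[C@@H]2O[C@H](CO)[C@@H](O)[C@H]2O)cc1`: in a functional assay on Huh-7 cells (Homo sapiens) for cytotoxicity, read by MTT assay, with a stated time of 3 days (on this read-out lower numbers stand for higher toxicity in this test and higher numbers for lower toxicity in this test), compound 1 gives > 100000 nM, which is a limit of the assay and not a number.
Compound 2, `O=C1CCCN1Cc1ncnc2c1ncn2[C@@H]1O[C@H](CO)[C@@H](O)[C@H]1O`: in this assay compound 2 gives 45000 nM.
Compound 3, `OCCSCc1ncnc2c1ncn2[C@@H]1O[C@H](CO)[C@@H](O)[C@H]1O`: in this assay compound 3 gives > 100000 nM, again a limit of the assay.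

Compound 3 therefore stands only at a limit in this assay; of the three values shown, two sit there (the limit of > 100000 nM in this assay, at which 2 of the 3 values shown sit). Among the measured compounds shown here, the one readable step that reaches compound 3 is an at least 2.2-fold higher number from compound 2 to compound 3 (0.34 log units; beyond the scatter), while a step that the two limits leave unreadable from compound 1 to compound 3 cannot be sized because both ends are limits.

The unmeasured compound 4, `COCc1ncnc2c1ncn2[C@@H]1O[C@H](CO)[C@@H](O)[C@H]1O`, differs from compound 3 only in one place: methoxy in place of (2-hydroxyethyl)sulfanyl on a saturated chain carbon bound to an aromatic carbon. For the measured compounds named here, no measured step changes this position in the same way, so the step from compound 3 to compound 4 has no direct precedent. With compound 3 already at the limit in this assay, and two of three measured compounds sitting there (the limit of > 100000 nM in this assay, at which 2 of the 3 values shown sit), compound 4 is expected to stay near that limit, with no step beyond the scatter: a step that the limit leaves unreadable from compound 3 to compound 4 is the expected outcome. In this assay compound 4 is estimated at 120000 nM, within a range from 40000 nM to 300000 nM.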

Compound 4, half-maximal cytotoxic concentration: > 100000 nM
Compound 4 gave a limit, no number; the forecaster's own chance of this, stated with the estimate: 70%; the middle value is on the limit's open side.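

In this assay compound 4 gives > 100000 nM, a limit of the assay and not a number. Among the compounds shown here, exchanging 2-oxopyrrolidin-1-yl for methoxy on a saturated chain carbon bound to an aromatic carbon gives an at least 2.2-fold higher number from compound 2 to compound 4 (0.34 log units; beyond the scatter), so compound 2 remains the only compound with a readable number. Methoxy has neither the sulfur nor the hydrogen-bond donor of (2-hydroxyethyl)sulfanyl, yet compound 4 still reads at the limit, and the steps from compound 3 to compound 4 and from compound 1 to compound 4 cannot be read, leaving the series at: the limit of > 100000 nM in this assay, at which 3 of the 4 values shown sit.

Going by these compounds, how far compound 1, compound 3 and compound 4 lie beyond the limit stays open, so no order among them can be given. Also open, on these data alone, is whether a value under the limit goes with 2-oxopyrrolidin-1-yl alone or would also appear with an amine or a longer alkyl chain at this place.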